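Solubility of a Positional Methoxy Isomer in a Phenoxy Series

This account rests on a few compounds, and the source may have more. Where it says the series, first, only, none or still open, it means among the compounds named here.

Measured compounds: compound 1 `COc1ccc(F)cc1CNCCCNc1ccnc2cc(Cc3ccc(C#N)cc3)ccc12` gives 4200 nM; compound 2 `COc1cccc(CNCCCNc2ccnc3cc(Oc4ccccc4)ccc23)c1O` gives 14500 nM; compound 3 `COc1ccc(Oc2ccc3c(NCCCNCc4cc(F)ccc4OC)ccnc3c2)cc1` gives 14500 nM.

In a physicochemical assay for solubility, with a stated time of 18 h, at pH 7.4 (on this read-out lower numbers stand for lower solubility and higher numbers for higher solubility), compound 3 stands level with compound 2 at the digits shown, the two together giving the highest of the three numbers, while compound 1 sits lowest. Among the compounds with values here, the only single-point step among the measured compounds is a 3.5-fold higher number from compound 1 to compound 3 (0.54 log units; beyond the scatter), which concerns the aryl group on the shared core rather than the change now at hand. Compound 4 `COc1cccc(Oc2ccc3c(NCCCNCc4cc(F)ccc4OC)ccnc3c2)c1` differs from compound 3 by 3-methoxyphenyl in place of 4-methoxyphenyl on an oxygen on an aromatic ring. Within the data shown here, no measured step bears directly on this rearrangement; what can be said is that compound 2, which carries a phenoxy group without any methoxy, gives the same number as compound 3, so the methoxy on that ring has not moved the read-out where it is present at all. The step of a 1.0-fold lower number from compound 3 to compound 4 (0.02 log units; within the scatter) is therefore expected to lie within the scatter. Compound 4 is estimated at 14000 nM, with a range of 6000 nM to 33000 nM.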

Compound 4, solubility: 14500 nM
The estimate for compound 4 lay 1.0-fold (0.02 log units) below the measured number; the range from low to high includes it.
By their numbers in this assay, from the lowest: compound 1; then compounds 2, 3 and 4 (each within the scatter of the next).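

In this assay, within the data shown here, moving the methoxy group, with 3-methoxyphenyl in place of 4-methoxyphenyl on an oxygen on an aromatic ring, gives no change at the digits printed from compound 3 to compound 4 (within the scatter) and so leaves the number unchanged, which no earlier pair could show for this rearrangement of the same atoms. The gap to the 4-cyanobenzyl compound also holds for the new isomer, at a 3.5-fold higher number from compound 1 to compound 4 (0.54 log units; beyond the scatter) and so is not tied to the 4-methoxyphenoxy group alone. Nothing at hand explains why the two isomers read alike.

The compounds shown leave open whether this level would hold with a carboxylic acid or an amine in place of the methoxy group on this ring. They also leave open whether the same indifference would appear with a longer chain on that oxygen.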